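Chloro on the benzyl of compound 2

The source may hold more compounds than are shown below. What is called first, only, known or untested is meant among the compounds shown, and "the series" means these compounds.

Compound 1 `Cn1c(-c2ccc(NC(=O)CN3CCN(c4ccccc4)CC3)cc2)nc(-c2ccccc2)c1-c1ccccc1` and compound 2 `Cn1c(-c2ccc(NC(=O)CN3CCN(Cc4ccccc4)CC3)cc2)nc(-c2ccccc2)c1-c1ccccc1` share one core and differ only in the group on the ring amine nitrogen. In a functional assay on HT-29 cells (Homo sapiens) for cytotoxicity, read by MTT assay, with a stated time of 24 h, tested at 0.64 ug/mL (on this read-out higher numbers stand for a stronger effect at the one concentration tested and lower numbers for a weaker effect), compound 1 gives 17.3%, and compound 2 gives 15.5%. The step of a number 1.8 percentage points lower from compound 1 to compound 2 (within the scatter) is within the scatter, so compound 2 holds the lowest of the two numbers without standing apart from compound 1. Compound 3 `Cn1c(-c2ccc(NC(=O)CN3CCN(Cc4ccc(Cl)cc4)CC3)cc2)nc(-c2ccccc2)c1-c1ccccc1` differs from compound 2 by chloro in place of hydrogen on an aromatic carbon. Among the compounds with values here, no measured step touches this change; the single step available, benzyl in place of phenyl on an amine nitrogen in a ring, stayed within the scatter of this assay. With nothing in the two numbers pointing either way, the step of a number 0.5 percentage points lower from compound 2 to compound 3 (within the scatter) is expected to stay within the scatter. Compound 3 is therefore estimated at 15%, with a range from 6% to 26%.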

Compound 3, a percentage reported as activity, at one concentration (the size of the read-out at that concentration, not a potency): 11.3%
Estimate against measurement, compound 3: 3.7 percentage points above; the measured number falls inside the stated range.
By their numbers in this assay, from the lowest: compounds 3, 2 and 1 (each within the scatter of the next).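

Chloro in place of hydrogen on an aromatic carbon of the benzyl gives a step that stays within the scatter in this assay (a number 4.2 percentage points lower from compound 2 to compound 3 (within the scatter)), so compound 3 does not stand apart from compound 2 at this position. The wider replacement, 4-chlorobenzyl in place of phenyl on the ring amine nitrogen, also stays within the scatter (a number 6 percentage points lower from compound 1 to compound 3 (within the scatter)), so neither group change on this nitrogen shown so far separates the compounds in this read-out. Nothing given here bears on what lies behind these numbers.

On these data alone, whether a methoxy, an amine or a carboxylic acid at the same place on the benzyl would give a step beyond the scatter remains open. Also open, as far as these compounds go, is what a longer chain between the ring amine nitrogen and the aromatic ring would do.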